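An Ethyl Ester Replaces a Methyl Ether

This account rests on a few compounds, and the source may have more. Where it says the series, first, only, none or still open, it means among the compounds named here.

Compound 1 `CC(=O)N1CCN(S(=O)(=O)c2ccc(F)cc2)C(CO)C1` reaches the limit >= 4 h in a physicochemical assay for metabolic stability, read by LC-MS, in phosphate buffer, tested at 1 uM; on this read-out higher numbers stand for a longer-lived compound and lower numbers for a shorter-lived compound.
Compound 2 `CC(=O)OCC1CN(C(C)=O)CCN1S(=O)(=O)c1ccc(F)cc1` reaches the limit >= 4 h in this assay.
Compound 3 `COCC1CN(C(C)=O)CCN1S(=O)(=O)c1ccc(F)cc1` reaches the limit >= 4 h in this assay.

Compound 3 therefore stands where its two companions stand, at the limit of >= 4 h in this assay, at which 3 of the 3 values shown sit, and no ordering among the three can be read. The steps between them, a step that the two limits leave unreadable from compound 1 to compound 2, a step that the two limits leave unreadable from compound 1 to compound 3 and a step that the two limits leave unreadable from compound 2 to compound 3, are each hidden by the limit, so none of them carries a readable size.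

Compound 4 `CCOC(=O)C1CN(C(C)=O)CCN1S(=O)(=O)c1ccc(F)cc1` differs from compound 3 by ethoxycarbonyl in place of methoxymethyl on a saturated ring carbon. Of the measured steps, only those touching the same carbon-bound oxygen position are related, and all three were unreadable; they give no size and no direction for this assay. The expectation for compound 4 thus rests on the three measured compounds all sitting at the limit, and a step of about a number no higher from compound 3 to compound 4 (the limit leaves the size open) is expected. Compound 4 is estimated at 4 h, within 1.5 h to 8 h, with a fair chance that the assay again reports only its limit.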

Compound 4, half-life: >= 4 h
Compound 4 gave a limit, no number; the forecaster's own chance of this, stated with the estimate: 60%; the middle value sits exactly at the limit.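

In this assay compound 4 gives >= 4 h as a limit, not a number. Its steps from compound 1, compound 2 and compound 3 therefore cannot be read: the limit of >= 4 h in this assay, at which 4 of the 4 values shown sit. The compounds shown leave open how the four compare in this assay beyond that limit.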